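The source may report more compounds than this note shows. Statements on the series, on what has been measured and on what is new or still open speak of the compounds shown alone.

Measured so far:
Compound 1 `O=C(O)c1cnn(Cc2cc(Br)ccc2OCc2ccccc2)c1` — in a functional assay on CHO-K1 cells for antagonist activity at prostaglandin E2 receptor EP1 subtype (Homo sapiens), read by FLIPR (a lower number here means a stronger inhibitor, a higher number a weaker inhibitor), compound 1 gives < 2000 nM
Compound 2 `Cc1cc(C(=O)O)nn1Cc1cc(Br)ccc1OCc1ccc(F)cc1F` — in this assay compound 2 gives 2.63 nM

The value recorded for compound 1 is a limit of the assay and not a number (the limit of < 2000 nM in this assay, at which 1 of the 2 values shown sits). For the measured compounds named here, compound 2 therefore stands as the only compound with an actual number, at 2.63 nM, and nothing else among the measured values can be set against it. Compound 3 `Cc1cc(C(=O)O)nn1Cc1cc(Br)ccc1OCc1ccccc1Cl` differs from compound 2 by 2-chlorophenyl in place of 2,4-difluorophenyl on a saturated chain carbon bound to an oxygen on an aromatic ring. Going by the values given here, no pair of measured compounds shares this change, so there is no measured step by which to size it. With only compound 2 and its value of 2.63 nM to go on, a step within the usual scatter, or at most a modest loss, is what is expected. Compound 3 is estimated at 4 nM, with a likely range from 1 nM to 15 nM. The step this expectation implies, a 1.5-fold higher number from compound 2 to compound 3 (0.18 log units; within the scatter), is small.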

Compound 3, inhibition constant: 28.8 nM
Compound 3: middle estimate off by 7.2-fold (0.86 log units), on the low side, and the stated range ends below it.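

In this assay, the ring on the saturated chain carbon bound to an oxygen on an aromatic ring proves sensitive to substitution: 2-chlorophenyl in place of 2,4-difluorophenyl gives an 11-fold higher number from compound 2 to compound 3 (1.04 log units; beyond the scatter). For the compounds shown here, this is the only measured step at this place, and it lies beyond the scatter, though compound 3 still gives a real number at 28.8 nM. Nothing measured here accounts for the size of this step.

The change removes two fluorines and brings in one chlorine in a single step, so these compounds cannot show which part of it carries the difference. From the compounds shown here alone, a 2-fluorophenyl, a 4-fluorophenyl or a 2,4-dichlorophenyl group at the same place would separate those parts, and how any of them would read in this assay remains open.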